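A Methyl Removed on Two Different Cores

The compounds below may be only part of what the source reports. "The series", "measured", "known", "first", "only" and "open" are said of these compounds alone.

Compound 1 `CN(C)c1ccc(/C=C/c2c(F)cccc2Cl)cc1` and compound 2 `CNc1ccc(/C=C/c2c(F)cccc2Cl)cc1` share one core and differ in a single place, (hydrogen in place of methyl on a nitrogen on an aromatic ring). In a functional assay on LS174T cells (Homo sapiens) for antiproliferative activity (on this read-out higher numbers stand for weaker inhibition and lower numbers for stronger inhibition), compound 1 gives 19.2 nM. In this assay compound 2 gives 7.6 nM. Measured as a step, this is a 2.5-fold lower number from compound 1 to compound 2 (0.40 log units; beyond the scatter).

Compound 3 `CN(C)c1ncc(/C=C/c2c(F)cccc2Cl)cn1` carries the dimethylamino group on another core, and the difference between the two cores is not broken down here. In this assay compound 3 reaches only a limit, > 200 nM, so no number is known for it. That limit is the limit of > 200 nM in this assay, at which 1 of the 3 values shown sits.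

Compound 4 `CNc1ncc(/C=C/c2c(F)cccc2Cl)cn1` has not yet been measured. It differs from compound 3 by hydrogen in place of methyl on a nitrogen on an aromatic ring, the same change that turns compound 1 into compound 2, at a place described in exactly the same words.

For compound 4 in this assay the step is expected to be a step that the limit leaves unreadable from compound 3 to compound 4, and that expectation rests on a 2.5-fold lower number from compound 1 to compound 2 (0.40 log units; beyond the scatter). Since the starting point of compound 3 is only a limit rather than a number, the expected value for compound 4 is wide. Compound 4 is estimated at about 250 nM. The lower end for compound 4 is estimated at 80 nM. The upper end for compound 4 is estimated at 800 nM.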

Compound 4, half-maximal inhibitory concentration: > 200 nM
Compound 4 ended at the assay's limit (the forecaster's own chance of this, stated with the estimate: 55%); the middle value does not contradict the limit.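

In this assay compound 3 and compound 4 both reach only a limit, so no step between them can be read: the limit of > 200 nM in this assay, at which 2 of the 4 values shown sit.

The compounds shown leave open whether hydrogen in place of methyl changes the read-out at all on the core of compound 3, and so whether it matches the change on the other core, a 2.5-fold lower number from compound 1 to compound 2 (0.40 log units; beyond the scatter).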